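A Fluoro on the Phenyl of Compound 3

The source may hold more compounds than are shown below. What is called first, only, known or untested is meant among the compounds shown, and "the series" means these compounds.

In a functional assay on K562 cells (Homo sapiens) for cytotoxicity, read by trypan blue exclusion, with a stated time of 96 h (a lower number here means a stronger inhibitor, a higher number a weaker inhibitor), compound 1 `COC(=O)CNc1cc(NS(=O)(=O)/C=C/c2c(OC)cc(OC)cc2OC)ccc1OC` gives 350 nM and compound 2 `COC(=O)C(C)Nc1cc(NS(=O)(=O)/C=C/c2c(OC)cc(OC)cc2OC)ccc1OC` gives 300 nM. These two values lie within the scatter of each other, as a 1.2-fold lower number from compound 1 to compound 2 (0.07 log units; within the scatter) shows. Compound 3 `COC(=O)C(Nc1cc(NS(=O)(=O)/C=C/c2c(OC)cc(OC)cc2OC)ccc1OC)c1ccccc1` gives 2500 nM, the weakest result of the three, with steps to it from both other compounds beyond the scatter.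

Compound 4 `COC(=O)C(Nc1cc(NS(=O)(=O)/C=C/c2c(OC)cc(OC)cc2OC)ccc1OC)c1ccc(F)cc1` keeps the structure of compound 3 except for fluoro in place of hydrogen on an aromatic carbon, para to a large group: fluoro in place of hydrogen on an aromatic carbon. The closest evidence comes from the two steps that introduced the phenyl, a 7.1-fold higher number from compound 1 to compound 3 (0.85 log units; beyond the scatter) and an 8.3-fold higher number from compound 2 to compound 3 (0.92 log units; beyond the scatter). Both are modest, and both show that the number responds to a change at this chain carbon. Among the measured compounds shown here, neither tests a substituent on the phenyl itself, and no measured pair does so. A single fluoro replaces a much smaller piece of the structure than either of those steps did, so a change of their size is not expected, and no clear direction can be drawn from the data. The expected step is a 1.1-fold lower number from compound 3 to compound 4 (0.06 log units; within the scatter), which would stay within the scatter. The estimate for compound 4 is 2200 nM, with an expected range from 900 nM to 5500 nM.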

Compound 4, half-maximal inhibitory concentration: 2500 nM
For compound 4 the middle estimate is 1.1-fold (0.06 log units) below the measured one; the range from low to high includes it.
By their numbers in this assay, from the lowest: compounds 2 and 1 (each within the scatter of the next); then compounds 3 and 4 (each within the scatter of the next).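

The phenyl itself had not been tested until now, and in this assay fluoro in place of hydrogen on this ring gives no change at the digits printed from compound 3 to compound 4 (within the scatter). So the position para to the large group tolerates this one-atom change without any shift beyond the scatter, whereas replacing the whole group at the chain carbon did move the number. The 4-fluorophenyl group also stands apart from the smaller substituents at that carbon, with an 8.3-fold higher number from compound 2 to compound 4 (0.92 log units; beyond the scatter) and a 7.1-fold higher number from compound 1 to compound 4 (0.85 log units; beyond the scatter), so it matches the phenyl of compound 3 in separating from compound 1 and compound 2. Nothing measured here bears on why the fluoro leaves the number in place.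

From the compounds shown here alone, a single substituent at a single ring position cannot show whether the phenyl is insensitive to change in general, and larger groups at this place, such as methoxy, trifluoromethyl or an amine, remain open. Going by these compounds, it is also open whether a carboxylic acid in place of the methyl ester would shift the number for compound 3 and compound 4 alike.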